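This account rests on a few compounds, and the source may have more. Where it says the series, first, only, none or still open, it means among the compounds named here.

Measured so far in a functional assay on MCF7 cells (Homo sapiens) for inhibition, read by MTT assay, with a stated time of 72 h; on this read-out lower numbers stand for stronger inhibition and higher numbers for weaker inhibition:
- compound 1 `Cc1cc(Nc2cc(-c3cccs3)[nH]n2)n2nc(SCc3ccc(Br)cc3)nc2n1`: 5370 nM
- compound 2 `Cc1cc(Nc2ccn(Cc3cccc4ccccc34)n2)n2nc(SCc3ccc(Br)cc3)nc2n1`: 4310 nM

Compound 1 stands level with compound 2, as the two values lie within the scatter of each other and show no order.

The step under consideration leads to compound 3 `Cc1cc(Nc2cc(-c3ccccc3)[nH]n2)n2nc(SCc3ccc(Br)cc3)nc2n1`, with phenyl in place of thiophen-2-yl on an aromatic carbon of a five-membered aromatic ring with 2 nitrogen: phenyl in place of thiophen-2-yl on an aromatic carbon. Within the data shown here, no measured step covers this exchange, so the evidence is thin. Among the measured compounds shown here, the only guide is that compound 2, with a different substitution, gives 4310 nM, within the scatter of compound 1. In this assay, therefore, no change beyond the scatter is expected, and no direction is favoured. The estimated step is a 1.1-fold lower number from compound 1 to compound 3 (0.03 log units; within the scatter). For compound 3 the expected value is 5000 nM, with an estimated range of 2000 nM to 12000 nM.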

Compound 3, half-maximal inhibitory concentration: 2720 nM
Estimate against measurement, compound 3: 1.8-fold (0.26 log units) above; the range from low to high includes it.
By their numbers in this assay, from the lowest: compounds 3, 2 and 1 (each within the scatter of the next).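

In this assay the exchange at this position has its first direct reading: phenyl in place of thiophen-2-yl on an aromatic carbon gives a 2.0-fold lower number from compound 1 to compound 3 (0.30 log units; within the scatter) and so shows no change beyond the scatter. On this carbon of the five-membered aromatic ring with 2 nitrogen, a five-membered aromatic ring with a sulfur hetero atom and a six-membered aromatic ring of carbon only therefore read alike, with the rest of the molecule held constant. Nothing available explains this equivalence.

Still open, going by these compounds, is whether this position stays as undemanding with a group of another kind, such as an amine, a carboxylic acid or a longer alkyl chain. Also open, on these data alone, is whether a substituent on the phenyl ring, such as methoxy or chlorine, would move the number beyond the scatter.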